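Cytotoxicity notes on the acid-tailed biaryl amide series

A few compounds are considered here, and "the series" means these few. Any claim that something is new, unique, unknown or untested is made for them only; others in the source may bear on it.

Compound 1 `CC(C)N(Cc1cccc(OCCCCCC(=O)O)c1)C(=O)c1ccc(-c2cccc(Oc3ccccc3)c2)cc1` and compound 2 `Cc1nnc(-c2cccc(-c3ccc(C(=O)N(Cc4cccc(OCCCCCC(=O)O)c4)C(C)C)cc3)c2)o1` share the core of compound 1 and differ only in the group on its outer ring. In an ADME assay on BJ cells (Homo sapiens) for cytotoxicity, read by CellTiter-Glo and resazurin assay, with a stated time of 72 h (a lower number here means that less compound is needed, a higher number that more compound is needed for the effect), compound 1 gives only a limit, > 18700 nM. In this assay compound 2 likewise gives only a limit, > 26000 nM. The step that the two limits leave unreadable from compound 1 to compound 2 is therefore unreadable, with both values resting at limits (the limit of > 18700 nM in this assay, at which 1 of the 2 values shown sits, (the limit of > 26000 nM in this assay, at which 1 of the 2 values shown sits)). Compound 3 `CC(C)N(Cc1cccc(OCCCCCC(=O)O)c1)C(=O)c1ccc(-c2ccc(Cl)c(Cl)c2)cc1` follows from compound 2 by the change (3,4-dichlorophenyl in place of 3-(5-methyl-1,3,4-oxadiazol-2-yl)phenyl on an aromatic carbon). Among the compounds with values here, the only measured step is the unreadable one from compound 1 to compound 2, so no measured step gives a size to expect for this change, and no direction beyond the scatter can be drawn from the data. A step of an at least 1.0-fold lower number from compound 2 to compound 3 (0.01 log units; that floor lies within the scatter) close to zero is therefore expected. Compound 3 is estimated at 25000 nM, in the range 8000 nM to 60000 nM, and is expected most likely to return again only a limit.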

Compound 3, half-maximal effective concentration: > 26000 nM
Compound 3 ended at the assay's limit; the forecaster's own chance of this, stated with the estimate: 70%; middle value at least 1.0-fold (0.01 log units) away from the limit.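

No new step can be read from compound 2 to compound 3, since both rest at the same limit: the limit of > 26000 nM in this assay, at which 2 of the 3 values shown sit.

The compounds shown leave open whether any change on the outer ring shifts the half-maximal effective concentration in this assay, and by how much.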